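Ethyl for tert-butyl on the outer phenyl ring

The source may report more compounds than this note shows. Statements on the series, on what has been measured and on what is new or still open speak of the compounds shown alone.

The measured compounds and their values:
compound 1 `CCCC[C@H](Oc1ncc(-c2ccccc2)cn1)c1ccc(C(=O)NCCC(=O)O)cc1` 8500 nM
compound 2 `CCCC[C@@H](Oc1ncc(-c2ccccc2)cn1)c1ccc(C(=O)NCCC(=O)O)cc1` 9300 nM
compound 3 `CCCCC(Oc1ncc(-c2ccc(C(C)(C)C)cc2)cn1)c1ccc(C(=O)NCCC(=O)O)cc1` 6000 nM

In a functional assay on cells for antagonist activity at Glucagon receptor (Homo sapiens), read by luminescence and cAMP accumulation, with stated times of 10 min and 30 min (a lower number here means a stronger inhibitor, a higher number a weaker inhibitor), compound 3 gives the lowest of the three numbers. The others lie close by: compound 1 gives 8500 nM and compound 2 gives 9300 nM, both within the scatter of compound 3. The only step measured so far is a 1.1-fold higher number from compound 1 to compound 2 (0.04 log units; within the scatter), and it concerns nothing but the configuration at the saturated chain carbon, as shown by the fact that compounds 1 and 2 differ only in the configuration as drawn. It therefore says nothing about groups on the outer phenyl ring.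

Compound 4 `CCCCC(Oc1ncc(-c2ccc(CC)cc2)cn1)c1ccc(C(=O)NCCC(=O)O)cc1` differs from compound 3 by ethyl in place of tert-butyl on an aromatic carbon. Compounds 1 and 2, which carry no group at that position, show numbers close to that of compound 3, so the tert-butyl group in compound 3 brings no change beyond the scatter. An ethyl group sits between the two cases and gives no ground to expect a step beyond the scatter in this assay in either direction. The estimated step is a 1.2-fold higher number from compound 3 to compound 4 (0.07 log units; within the scatter), and compound 4 is expected to give 7000 nM, with a range from 3500 nM to 14000 nM.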

Compound 4, half-maximal inhibitory concentration: 17700 nM
For compound 4 the middle estimate is 2.5-fold (0.40 log units) below the measured one; measured number outside the range, above it.
By their numbers in this assay, from the lowest: compounds 3, 1, 2 and 4 (each within the scatter of the next, the first and the last beyond it).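

In this assay, going from 4-(tert-butyl)phenyl to 4-ethylphenyl gives a 3.0-fold higher number from compound 3 to compound 4 (0.47 log units; beyond the scatter), a modest step and the first one beyond the scatter at this position. Among these compounds, the earlier compounds offered only a step in configuration at the saturated chain carbon, so this is the first measured sign that the number responds to the group carried on the aromatic carbon, here with tert-butyl, of 4 heavy atoms, leaving and ethyl, of 2 heavy atoms, entering. Among the compounds shown here, the only evidence at hand concerns configuration at the chain carbon and does not bear on this change, so the reason for the step remains unknown.

The compounds shown leave open how methyl, isopropyl or a longer chain such as butyl would read at this place, and whether an amine or a carboxylic acid there would fit with the two carbon-only groups. They also leave open whether the step would hold with the chain carbon drawn in a single configuration, as compound 3 and compound 4 are drawn without one.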